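Shifting the chlorine on the benzyl group: working notes

The source may report more compounds than this note shows. Statements on the series, on what has been measured and on what is new or still open speak of the compounds shown alone.

Four compounds share a thioether-bearing core and are followed in a functional assay on the whole organism (artery, strain albino) with Rattus norvegicus as the target, with a stated time of 300 min, at a dose of 10 mg/kg by the oral route; on this read-out higher numbers stand for more inhibition at the one dose given (going by the name of the read-out) and lower numbers for less inhibition. Compound 1, `COc1ccc(C2N=C(SCc3ccccc3Cl)NC(C)=C2C(=O)Nc2ccc(F)cc2)cc1OC`, gives 35.9% in this assay. Within the data shown here, compound 2, `COc1ccc(C2N=C(SCc3cccc(Cl)c3)NC(C)=C2C(=O)Nc2ccc(F)cc2)cc1OC`, differs from it by 3-chlorophenyl in place of 2-chlorophenyl on a saturated chain carbon bound to a sulfur and gives 16.4% in this assay, so the step of a number 19.5 percentage points lower from compound 1 to compound 2 (beyond the scatter) is the one measured example of this change.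

Compound 3, `CC1=C(C(=O)Nc2ccc(Br)cc2)C(c2ccc(Cl)cc2Cl)N=C(SCc2ccccc2Cl)N1`, gives 36.4% in this assay, a number within the scatter of compound 1 and beyond the scatter of compound 2. The difference between the core of compound 3 and the core of compound 1 is not broken down here.

Compound 4, `CC1=C(C(=O)Nc2ccc(Br)cc2)C(c2ccc(Cl)cc2Cl)N=C(SCc2cccc(Cl)c2)N1`, is not yet measured. It differs from compound 3 by 3-chlorophenyl in place of 2-chlorophenyl on a saturated chain carbon bound to a sulfur, the same change as from compound 1 to compound 2, made at the same place. Among the measured compounds shown here, only this single pair supports the expectation, and the cores of compound 1 and compound 3 differ in more than one place, so the carry-over is uncertain. For the measured compounds named here, compound 4 is nevertheless expected to show a step of a number 18.4 percentage points lower from compound 3 to compound 4 (beyond the scatter) in this assay, a size resting on the single measured step of a number 19.5 percentage points lower from compound 1 to compound 2 (beyond the scatter). Compound 4 is thus estimated at 18% in this assay, with the range 5% to 32%.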

Compound 4, a percentage reported as inhibition, in the whole organism at one dose (the size of the read-out at that dose, not a potency): 18.5%
Compound 4: the middle estimate sits 0.5 percentage points below what was measured; the range from low to high includes it.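

In this assay, 3-chlorophenyl in place of 2-chlorophenyl on a saturated chain carbon bound to a sulfur gives a number 17.9 percentage points lower from compound 3 to compound 4 (beyond the scatter), so the fall seen on the core of compound 1 appears again on the core of compound 3. Set side by side, the two measured steps agree in direction and cannot be told apart in size: the same change on two cores in this assay, a number 19.5 percentage points lower (beyond the scatter) from compound 1 to compound 2 and a number 17.9 percentage points lower (beyond the scatter) from compound 3 to compound 4, 1.6 percentage points apart, within the scatter of two such steps. For these two pairs, the change therefore carries over between cores that differ in more than one place, but two pairs at one dose in one read-out do not show that it would carry over to any other core, nor do they explain why the step occurs.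

The compounds shown carry only 2-chlorobenzyl and 3-chlorobenzyl on the sulfur, so it remains open how an unsubstituted benzyl, a bromobenzyl or a longer chain between the sulfur and the phenyl ring would read out on either core. Also open, from the compounds shown here alone, is whether the step holds with an amine or a carboxylic acid on the benzyl ring, and whether it would look the same at doses other than the single one given here.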